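Swapping Phenoxy for Dimethylamino on a Shared Core

The compounds below may be only part of what the source reports. "The series", "measured", "known", "first", "only" and "open" are said of these compounds alone.

Compound 1 `Nc1cccc(Nc2c(C(=O)NCc3ccc(F)cc3)nc(Br)c3cccnc23)c1` and compound 2 `N[C@H]1CC[C@H](Nc2c(C(=O)NCc3ccc(Oc4ccccc4)cc3)nc(Br)c3cccnc23)CC1` were both tested in a functional assay on MCF7 cells (Homo sapiens) for cytotoxicity, read by MTT assay, with a stated time of 72 h; a higher number here means a weaker inhibitor, a lower number a stronger inhibitor. Compound 1 gives 8000 nM. Compound 2 gives 7900 nM, the lower of the two numbers, but it lies within the usual scatter of compound 1, so the two cannot be told apart. For compound 3 `O=C(NCc1ccc(F)cc1)c1nc(Br)c2cccnc2c1NCc1ccc(F)cc1` the entry in this assay reads "not determined" (no result reported), so no result was reported. Compound 4 `CN(C)c1ccc(CNC(=O)c2nc(Br)c3cccnc3c2N[C@H]2CC[C@H](N)CC2)cc1` has not yet been tested; it differs from compound 2 in one place: dimethylamino in place of phenoxy on an aromatic carbon. Among the compounds with values here, no measured pair isolates this change, so the data give no guide to its size. The expected step of a 1.1-fold higher number from compound 2 to compound 4 (0.06 log units; within the scatter) is none beyond the scatter. Compound 4 is accordingly estimated at 9000 nM, within a range from 3000 nM to 27000 nM.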

Compound 4, half-maximal inhibitory concentration: 5000 nM
Compound 4: the middle estimate sits 1.8-fold (0.26 log units) above what was measured; measured number inside the range.
By their numbers in this assay, from the lowest: compounds 4, 2 and 1 (each within the scatter of the next).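

In this assay, dimethylamino in place of phenoxy gives a 1.6-fold lower number from compound 2 to compound 4 (0.20 log units; within the scatter). At this place on the aromatic ring, then, a group with a six-membered aromatic ring and a smaller group with no ring cannot be told apart. No supporting evidence bears on this result.

On these data alone, whether a carboxylic acid or a primary amine at the same place would give a number beyond the scatter remains open. So does whether the same swap would behave alike with another group on the shared core.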